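Trifluoromethoxy in place of methylsulfanyl: working notes on the series

The source may hold more compounds than are shown below. What is called first, only, known or untested is meant among the compounds shown, and "the series" means these compounds.

In a functional assay on J774 cells (Mus musculus) for cytotoxicity, read by resazurin assay (on this read-out lower numbers stand for stronger inhibition and higher numbers for weaker inhibition), compound 1 (`OCCCCCC(O)c1ccc(-c2ccc(F)cc2)cc1`) gives 18000 nM and compound 2 (`OCCCCCC(O)c1ccc(-c2ccc(O)cc2)cc1`) gives 15000 nM while compound 3 (`CSc1ccc(-c2ccc(C(O)CCCCCO)cc2)cc1`) gives 24000 nM on the same read-out. Compound 3 thus sits with the other two, inside the scatter of each. The next change leads to compound 4 (`OCCCCCC(O)c1ccc(-c2ccc(OC(F)(F)F)cc2)cc1`) and puts trifluoromethoxy in place of methylsulfanyl on an aromatic carbon para to a large group. Among the measured compounds shown here, no measured step covers this exact swap. Three steps at the same place bear on it: a 1.3-fold higher number from compound 1 to compound 3 (0.12 log units; within the scatter) for methylsulfanyl in place of fluoro, a 1.6-fold higher number from compound 2 to compound 3 (0.20 log units; within the scatter) for methylsulfanyl in place of hydroxy and a 1.2-fold lower number from compound 1 to compound 2 (0.08 log units; within the scatter) for hydroxy in place of fluoro. Each lies within the scatter, so no step beyond the scatter is expected here. The estimated step is a 1.3-fold lower number from compound 3 to compound 4 (0.12 log units; within the scatter) and it is expected to stay within the scatter. For compound 4 the estimated value is 18000 nM with an expected range from 9000 nM to 35000 nM as the likely span.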

Compound 4, half-maximal inhibitory concentration: 14000 nM
For compound 4 the middle estimate is 1.3-fold (0.11 log units) above the measured one, and the stated range covers the measured number.
By their numbers in this assay, from the lowest: compounds 4, 2, 1 and 3 (each within the scatter of the next).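

In this assay the change to trifluoromethoxy gives a 1.7-fold lower number from compound 3 to compound 4 (0.23 log units; within the scatter) even though five heavy atoms enter where two leave, on an aromatic carbon para to a large group. Against the other two compounds it gives a 1.1-fold lower number from compound 2 to compound 4 (0.03 log units; within the scatter) and a 1.3-fold lower number from compound 1 to compound 4 (0.11 log units; within the scatter) so that fluoro, hydroxy, methylsulfanyl and trifluoromethoxy all lie within the scatter of one another at this position. No measurement at hand explains this result.

On these data alone, whether an amine or a carboxylic acid on this same aromatic carbon would shift the number beyond the scatter remains open. Also open, as far as these compounds go, is what a longer chain in place of the hydroxy-bearing chain of the shared core would do on this read-out.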